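The source may hold more compounds than are shown below. What is called first, only, known or untested is meant among the compounds shown, and "the series" means these compounds.

Measured in an ADME assay on L02 cells (Homo sapiens) for antiproliferative activity, read by MTT assay, with a stated time of 48 h; on this read-out higher numbers stand for weaker inhibition and lower numbers for stronger inhibition:
Compound 1 `CCN(CC)CCNC(=O)c1ccc(C(CC)(CC)c2ccc(OCCC(O)(CC)CC)c(C)c2)n1CC`: 2290 nM
Compound 2 `C#CCCOC(=O)c1ccc(C(CC)(CC)c2ccc(OCCC(O)(CC)CC)c(C)c2)n1CC`: > 50000 nM

Compound 2 gives > 50000 nM, which is a limit of the assay and not a number. For the measured compounds named here, it is the one compound of the two that sits at the limit of > 50000 nM in this assay, at which 1 of the 2 values shown sits. Compound 3 `CCOC(=O)CN(C)C(=O)c1ccc(C(CC)(CC)c2ccc(OCCC(O)(CC)CC)c(C)c2)n1CC` keeps the shared core and carries ((ethoxycarbonyl)methyl)(methyl)amino in place of (but-3-yn-1-yl)oxy on a carbonyl carbon.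

Going by the values given here, only one measured step bears on this place: an at least 21-fold higher number from compound 1 to compound 2 (1.33 log units; beyond the scatter), a large step made when (but-3-yn-1-yl)oxy replaced (2-(diethylamino)ethyl)amino. That step shows that this carbonyl substituent can move the read-out strongly in this assay. Compound 3 brings back neither group, however, so the step offers only a loose guide. A small move towards lower numbers is expected, or none beyond the scatter, and compound 3 is expected to stay much nearer compound 2 than compound 1, with a real chance of reaching the limit too.

The expected change is an at least 1.2-fold lower number from compound 2 to compound 3 (0.09 log units; that floor lies within the scatter). For compound 3 the estimated value is 40000 nM, with an expected range of 12000 nM to 90000 nM.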

Compound 3, half-maximal inhibitory concentration: 1990 nM
Compound 3: middle estimate off by 20-fold (1.30 log units), on the high side; the measured number lies below the stated range.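

In this assay, the change to ((ethoxycarbonyl)methyl)(methyl)amino on the carbonyl carbon gives an at least 25-fold lower number from compound 2 to compound 3 (1.40 log units; beyond the scatter), so the high number of the ester with the (but-3-yn-1-yl)oxy group is not shared by every replacement of the (2-(diethylamino)ethyl)amino group. That group is also not needed for a value in this range, since the two amino substituents, which differ in everything but the nitrogen attached to the carbonyl carbon, give a 1.2-fold lower number from compound 1 to compound 3 (0.06 log units; within the scatter). The step from the ester can be read only as a floor, and compound 2 gives > 50000 nM, which is a limit and not a number: the limit of > 50000 nM in this assay, at which 1 of the 3 values shown sits.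

Among these three compounds, the two with a nitrogen on the carbonyl carbon stand apart from the one with an oxygen, but a single ester cannot show whether that atom or the rest of the but-3-yn-1-yl chain sets the difference. As far as these compounds go, a simple ethyl ester or a plain dimethylamino group at this place would separate the two, and it stays open whether a carboxylic acid in place of the ethoxycarbonyl group would keep the value of compound 3.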